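From thiophen-2-yl to thiophen-3-yl in compound 3

The compounds below may be only part of what the source reports. "The series", "measured", "known", "first", "only" and "open" are said of these compounds alone.

Of the compounds shown here, three have been tested in a functional assay on HepG2 cells (Homo sapiens) for antiproliferative activity, read by XTT assay, with a stated time of 72 h (on this read-out higher numbers stand for weaker inhibition and lower numbers for stronger inhibition), and none has yet given a number. Compound 1, `CSc1ncnc2c1c(-c1ccoc1)cn2[C@@H]1O[C@H](CO)[C@@H](O)[C@H]1O`, gives > 15000 nM, which is a limit. Compound 2, `Nc1nc(N)c2c(-c3ccco3)cn([C@@H]3O[C@H](CO)[C@@H](O)[C@H]3O)c2n1`, gives > 20000 nM, also a limit. Compound 3, `Nc1nc(N)c2c(-c3cccs3)cn([C@@H]3O[C@H](CO)[C@@H](O)[C@H]3O)c2n1`, gives > 20000 nM, again a limit, so its standing is known only as a limit.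

Compound 4, `Nc1nc(N)c2c(-c3ccsc3)cn([C@@H]3O[C@H](CO)[C@@H](O)[C@H]3O)c2n1`, has the same atoms as compound 3, joined differently: thiophen-3-yl in place of thiophen-2-yl on an aromatic carbon. The thiophene ring stays, and only the way it is joined to the aromatic carbon of the shared core changes.

Among the compounds with values here, one measured step bears on this, a step that the two limits leave unreadable from compound 2 to compound 3, where thiophen-2-yl replaced furan-2-yl. Its size cannot be read, so it offers no sign of a step in either direction. No change beyond the scatter is therefore expected in this assay, and a further limit is the likeliest result.

The expected step is a number no higher from compound 3 to compound 4 (the limit leaves the size open). For compound 4 the estimate is 20000 nM, with an expected range of 9000 nM to 40000 nM.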

Compound 4, half-maximal inhibitory concentration: > 20000 nM
Compound 4 was reported as a limit; the forecaster's own chance of this, stated with the estimate: 85%; the middle value lies on the limit itself.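

Compound 4, like compound 2 and compound 3, is reported only as a limit, so the steps among these three compounds cannot be read. The compounds shown leave open whether any group on the shared core would give a number rather than a limit.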